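Side chain extension on the shared core

A few compounds are considered here, and "the series" means these few. Any claim that something is new, unique, unknown or untested is made for them only; others in the source may bear on it.

compound 1 `C=CCOc1cc(C2CNC(=O)C2)ccc1OC`: > 1000000 nM
compound 2 `CCCCOc1cc(C2CNC(=O)C2)ccc1OC`: > 1000000 nM

In an assay on isolated protein for inhibition of phosphodiesterase 1 (Bos taurus), read by cGMP accumulation, in the presence of a further agent that is not named here (a higher number here means a weaker inhibitor, a lower number a stronger inhibitor), compound 1 gives > 1000000 nM, which is a limit of the assay and not a number. In this assay compound 2 gives > 1000000 nM, likewise a limit. The step that the two limits leave unreadable from compound 1 to compound 2 is therefore not readable. Compound 2 stands only at the limit of > 1000000 nM in this assay, at which 2 of the 2 values shown sit. Compound 3 `CCCCNC(=O)CCCOc1cc(C2CNC(=O)C2)ccc1OC` carries butylcarbamoyl in place of methyl on a saturated chain carbon, three bonds along the chain from an oxygen on an aromatic ring. Among the measured compounds shown here, the only measured step on the chain, from compound 1 to compound 2, has no readable size, so no direction can be set for this assay. Compound 3 is expected to give 1000000 nM, between 300000 nM and 3000000 nM, an estimated step of a number no higher from compound 2 to compound 3 (the limit leaves the size open), most likely again reported as a limit.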

Compound 3, half-maximal inhibitory concentration: > 1000000 nM
Compound 3: only a limit was reported; the forecaster's own chance of this, stated with the estimate: 85%; the middle value sits exactly at the limit.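

In this assay compound 3 gives > 1000000 nM, a limit of the assay and not a number, so no size can be read for the change from compound 2 to compound 3. The compounds shown leave open whether any side chain on the shared core gives a measurable value in this assay.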